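This account rests on a few compounds, and the source may have more. Where it says the series, first, only, none or still open, it means among the compounds named here.

Compound 3 `S=c1oc(-c2ccc3c(c2)OCCO3)nn1CN1CCN(c2ccccc2Cl)CC1` stands at the floor of what is shown: in a functional assay on SW 1116 cells (Homo sapiens) for antiproliferative activity, read by MTT assay, with a stated time of 48 h (on this read-out lower numbers stand for stronger inhibition and higher numbers for weaker inhibition), compound 3 gives > 50000 nM, which is a limit of the assay and not a number. Compound 1 `S=c1oc(-c2ccc3c(c2)OCCO3)nn1CN1CCN(c2cccc(Cl)c2)CC1` gives > 50000 nM, likewise a limit. Compound 2 `COc1cccc(N2CCN(Cn3nc(-c4ccc5c(c4)OCCO5)oc3=S)CC2)c1` gives > 50000 nM, again a limit. The steps a step that the two limits leave unreadable from compound 1 to compound 2, a step that the two limits leave unreadable from compound 1 to compound 3 and a step that the two limits leave unreadable from compound 2 to compound 3 therefore have no readable size, all three because of the limit of > 50000 nM in this assay, at which 3 of the 3 values shown sit. Compound 4 `S=c1oc(-c2ccc3c(c2)OCCO3)nn1CN1CCN(c2ccccn2)CC1` differs from compound 3 by pyridin-2-yl in place of 2-chlorophenyl on an amine nitrogen in a ring. Going by the values given here, none of the measured steps bears on this change in a readable way; the series shows only limits. The expected step that the limit leaves unreadable from compound 3 to compound 4 is none beyond the scatter. Compound 4 is accordingly estimated at 60000 nM, within 20000 nM to 200000 nM, most probably reported again as a limit.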

Compound 4, half-maximal inhibitory concentration: 9490 nM
Estimate against measurement, compound 4: 6.3-fold (0.80 log units) above; measured number below the stated range.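

In this assay, the group on the amine nitrogen in a ring is now the first place in the series with a readable effect: pyridin-2-yl gives an at least 5.2-fold lower number from compound 3 to compound 4 (0.72 log units; beyond the scatter), and likewise an at least 5.2-fold lower number from compound 2 to compound 4 (0.72 log units; beyond the scatter) and an at least 5.2-fold lower number from compound 1 to compound 4 (0.72 log units; beyond the scatter). Among the four groups shown here, only the aromatic ring with a hetero atom comes off the limit, while 2-chlorophenyl, 3-chlorophenyl and 3-methoxyphenyl stay on it. All three sizes are lower bounds only, because each starting compound sits at a limit: the limit of > 50000 nM in this assay, at which 3 of the 4 values shown sit.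

From the compounds shown here alone, whether unsubstituted phenyl, pyridin-4-yl or pyrimidin-2-yl would match pyridin-2-yl at this place remains open. Also open, going by these compounds, is whether the remaining activity of compound 4 can be improved by a change elsewhere on the shared core.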